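A few compounds are considered here, and "the series" means these few. Any claim that something is new, unique, unknown or untested is made for them only; others in the source may bear on it.

Working notes on the series. The measure throughout is an assay on isolated protein for inhibition of long-chain fatty acid transport protein 1 (Homo sapiens); a higher number here means a weaker inhibitor, a lower number a stronger inhibitor. Compound 1 `CC/C(=N/OC)c1ccc2oc(CSc3nnc(CNc4ccccc4)n3CC)nc2c1` carries a methoxy oxime side arm on the shared core. In this assay compound 1 gives only a limit, > 1000 nM, and no number. Compound 1 therefore stands at the limit of > 1000 nM in this assay, at which 2 of the 3 values shown sit, together with one other value in the set. Compound 2 `CCn1c(CNc2ccccc2)nnc1SCC(=O)Nc1ccc(C(=O)OC(C)(C)C)cc1` likewise gives only a limit in this assay, > 1000 nM. Compound 3 `CCOC(=O)c1ccc(NC(=O)CSc2nnc(CNc3ccccc3)n2CC)cc1` gives 330 nM in this assay. Going by the values given here, the single step joining two measured compounds is an at least 3.0-fold lower number from compound 2 to compound 3 (0.48 log units; beyond the scatter), an ester shortening at an oxygen that starts from a limit.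

Compound 4 `CC/C(=N/O)c1ccc2oc(CSc3nnc(CNc4ccccc4)n3CC)nc2c1` is the next member to be measured in this assay. It differs from compound 1 by hydrogen in place of methyl on an oxygen. Among the compounds with values here, the one measured step also removes carbons from an alkyl on an oxygen, but at an ester rather than at the oxime and from a limit, so it bears on the change to compound 4 only loosely, and no measured step touches the oxime itself. With compound 1 at a limit, no step beyond the scatter is expected in this assay; compound 4 is expected to give about 1500 nM, between 400 nM and 5000 nM, most probably again a limit. The expected step is a step that the limit leaves unreadable from compound 1 to compound 4.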

Compound 4, half-maximal inhibitory concentration: 260 nM
For compound 4 the middle estimate is 5.8-fold (0.76 log units) above the measured one; the whole stated range lies above it.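

On the oxime of the shared core, this assay gives the first readable result at this position: an at least 3.8-fold lower number from compound 1 to compound 4 (0.58 log units; beyond the scatter). From the compounds shown here alone, compound 1 gives only a limit, > 1000 nM, and the true size of this step stays open-ended because the methoxy member has no number: the limit of > 1000 nM in this assay, at which 2 of the 4 values shown sit. The earlier step concerned an ester oxygen, whereas this one shows that, for this pair, the change from methoxy to hydroxy on the oxime alone separates a limit from a measured number.

Only hydrogen and methyl are shown on this oxygen, so it remains open whether the result is specific to the free hydroxy or would extend to other small groups. Also open, going by these compounds, is whether an ethyl or acetyl group on that oxygen, or an amine in place of the oxime, would give a number in this assay or return to a limit.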